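Pyridin-3-yl for pyridin-4-yl: a positional step in the series

The source may report more compounds than this note shows. Statements on the series, on what has been measured and on what is new or still open speak of the compounds shown alone.

Of the compounds shown here, two carry numbers so far. Compound 1 `Nc1ccccc1NC(=O)c1ccc(CSC(=S)N2CCN(c3cccnc3)CC2)cc1` gives 76.9% in a functional assay on MGC-803 cells (Homo sapiens) for antiproliferative activity, read by CCK-8 assay, with a stated time of 72 h, tested at 8 uM; a lower number here means a weaker effect, a higher number a stronger effect of the compound at the concentration tested. Compound 2 `Nc1ccccc1NC(=O)c1ccc(CSC(=S)N2CCN(Cc3ccncc3)CC2)cc1` gives 79.3% in this assay. Between them stands a number 2.4 percentage points higher from compound 1 to compound 2 (within the scatter). Compound 2 holds the higher of the two numbers, but compound 1 sits within the scatter of it, so no order between the two is claimed.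

Compound 3 `Nc1ccccc1NC(=O)c1ccc(CSC(=S)N2CCN(Cc3cccnc3)CC2)cc1` is not yet measured. It differs from compound 2 by pyridin-3-yl in place of pyridin-4-yl on a saturated chain carbon bound to an amine nitrogen in a ring. Within the data shown here, only one measured step bears on this change, a number 2.4 percentage points higher from compound 1 to compound 2 (within the scatter), and it alters two things at once, the ring position and the insertion of a saturated carbon, so it covers the pyridin-3-yl against pyridin-4-yl pair only indirectly. Because a number 2.4 percentage points higher from compound 1 to compound 2 (within the scatter) lay within the scatter, no step beyond the scatter is expected in this assay for the change to compound 3, in either direction. The expected step reads a number 2.3 percentage points lower from compound 2 to compound 3 (within the scatter). Compound 3 is estimated at 77%, with a range from 66% to 88%.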

Compound 3, a percentage reported as inhibition, at one concentration (the size of the read-out at that concentration, not a potency): 64.6%
The estimate for compound 3 lay 12.4 percentage points above the measured number; measured number outside the range, below it.
By their numbers in this assay, from the lowest: compound 3; then compounds 1 and 2 (each within the scatter of the next).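

In this assay the pyridin-3-yl against pyridin-4-yl pair now separates: pyridin-3-yl in place of pyridin-4-yl on a saturated chain carbon bound to an amine nitrogen in a ring gives a number 14.7 percentage points lower from compound 2 to compound 3 (beyond the scatter), with the same atoms joined differently. Among these compounds, the saturated carbon can also be read on its own for the first time, since inserting it while the pyridin-3-yl group stays unchanged gives a number 12.3 percentage points lower from compound 1 to compound 3 (beyond the scatter), whereas the earlier pair, which changed both features at once, showed only a number 2.4 percentage points higher from compound 1 to compound 2 (within the scatter). No measurement at hand accounts for either new step.

On these data alone, whether pyridin-2-yl or a plain phenyl on the same saturated carbon would stand with compound 2 or with compound 3 in this assay remains open, as does the outcome for a longer chain such as (pyridin-3-yl)ethyl or (pyridin-4-yl)ethyl. The numbers are also single-concentration read-outs from one cell line, so they do not show whether the gap between compound 2 and compound 3 would hold as a difference in potency.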